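Heptyl in Place of Phenyl on the Ester Carbonyl

The source may report more compounds than this note shows. Statements on the series, on what has been measured and on what is new or still open speak of the compounds shown alone.

Compound 2 `CN(CCCc1ccccc1)Cc1cn(CC(O)COC(=O)c2ccccc2)nn1` gives 12% in an assay on nucleic acid for inhibition of Nucleic Acid, read by fluorescence, tested at 100 uM; a higher number here means more inhibition at the concentration tested (going by the name of the read-out), a lower number less inhibition. Compound 1 `CN(CCCc1ccccc1)Cc1cn(CC(O)COCc2ccccc2)nn1` gives 18% in this assay, and the step of a number 6 percentage points lower from compound 1 to compound 2 (within the scatter) shows that the two sit within the scatter of one another. Compound 3 `CCCCCCCC(=O)OCC(O)Cn1cc(CN(C)CCCc2ccccc2)nn1` differs from compound 2 by heptyl in place of phenyl on a carbonyl carbon. Among the compounds with values here, no measured step touches the substituent on the carbonyl carbon, so the only guide is the one step already seen, which stayed within the scatter. Compound 3 is therefore expected to show no change at the digits printed from compound 2 to compound 3 (within the scatter), nothing beyond the scatter. For compound 3 the estimate is 12%, with a range from 0% to 28%.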

Compound 3, a percentage reported as inhibition, at one concentration (the size of the read-out at that concentration, not a potency): 12%
Compound 3: middle estimate and measured number agree at the digits printed; the measured number falls inside the stated range.
By their numbers in this assay, from the lowest: compounds 2, 3 and 1 (each within the scatter of the next).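

In this assay, heptyl in place of phenyl on a carbonyl carbon brings no change at the digits printed from compound 2 to compound 3 (within the scatter), so a six-membered aromatic ring is not needed at this place to keep this level of inhibition. Heptylcarbonyl in place of benzyl on the same oxygen gives a number 6 percentage points lower from compound 1 to compound 3 (within the scatter), which shows that an open chain and the two ring-bearing groups cannot be told apart here. No supporting evidence bears on this result.

From the compounds shown here alone, whether an amine or a carboxylic acid at the end of this chain would move the number beyond the scatter remains open, as does the effect of a longer chain.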